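A few compounds are considered here, and "the series" means these few. Any claim that something is new, unique, unknown or untested is made for them only; others in the source may bear on it.

In a functional assay on MCF7 cells (Homo sapiens) for cytotoxicity, read by MTT assay, with a stated time of 72 h (on this read-out higher numbers stand for weaker inhibition and lower numbers for stronger inhibition), compound 1 `O=C1c2c[n+]([O-])c3ccccc3c2C(=O)c2c1c1ccccc1n2Cc1cn([C@H]2O[C@H](CO)[C@@H](O)[C@H]2O)nn1` gives 1490 nM, and compound 2 `O=C1c2c[n+]([O-])c3ccccc3c2C(=O)c2c1c1ccccc1n2Cc1cn([C@@H]2C[C@H](O)[C@@H](CO)O2)nn1` gives 110 nM. Compound 3 `CN1CCN(CCCCn2c3c(c4ccccc42)C(=O)c2c[n+]([O-])c4ccccc4c2C3=O)CC1`, which carries a 4-(4-methylpiperazin-1-yl)butyl chain on the shared core, gives 100 nM. That value lies within the scatter of compound 2 and well apart from compound 1.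

Compound 4 `CN1CCN(CCCn2c3c(c4ccccc42)C(=O)c2c[n+]([O-])c4ccccc4c2C3=O)CC1` differs from compound 3 by 4-methylpiperazin-1-yl in place of (4-methylpiperazin-1-yl)methyl on a saturated chain carbon, three bonds along the chain from an aromatic nitrogen. The same difference reads as 4-(4-methylpiperazin-1-yl)butyl to 3-(4-methylpiperazin-1-yl)propyl. Among the compounds with values here, the only measured step is a 14-fold lower number from compound 1 to compound 2 (1.13 log units; beyond the scatter), with hydrogen in place of hydroxy on a saturated ring carbon. Within the data shown here, it is large, but it lies elsewhere in the structure, and no measured pair varies this chain. Among the measured compounds shown here, it shows only that one small change can move this read-out far, which argues for a wide range and gives no direction. No step beyond the scatter is therefore expected, and the expected step is a 1.2-fold higher number from compound 3 to compound 4 (0.08 log units; within the scatter). Resting on the value of compound 3 at 100 nM, compound 4 is estimated at 120 nM, with an expected range of 40 nM to 350 nM.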

Compound 4, half-maximal inhibitory concentration: 220 nM
Beside the measured number, compound 4's estimate is 1.8-fold (0.26 log units) below it; the range from low to high includes it.
By their numbers in this assay, from the lowest: compounds 3, 2 and 4 (each within the scatter of the next, the first and the last beyond it); then compound 1.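

In this assay, within the data shown here, the shorter chain of compound 4 brings a 2.2-fold higher number from compound 3 to compound 4 (0.34 log units; beyond the scatter) and so gives the first measured pair that varies this chain on the shared core. It shows that, with the 4-methylpiperazin-1-yl group kept, removing one chain carbon three bonds along the chain from an aromatic nitrogen is enough to move the read-out modestly toward weaker inhibition, though this one pair sets a direction only for these two compounds. No available evidence accounts for the step.

The compounds shown leave open whether a 2-(4-methylpiperazin-1-yl)ethyl chain or a longer pentyl chain would extend this direction. They also leave open whether a morpholine or a dimethylamine could take the place of the 4-methylpiperazin-1-yl group at the chain end.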